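The compounds below may be only part of what the source reports. "The series", "measured", "known", "first", "only" and "open" are said of these compounds alone.

Series notes, step from compound 2 to compound 3.

Among the compounds with values here, the two measured members share one core and differ only at the substituent on the saturated carbon attached to the phenyl ring. Compound 1 `CCCC[S+]([O-])c1sc2nc(-c3nccs3)cc(-c3ccc(COC(=O)NCC)cc3)c2c1N` carries an ethylcarbamoyl on that oxygen; in an assay for inhibition of 15-hydroxyprostaglandin dehydrogenase [NAD(+)] (Homo sapiens), read by fluorescence, with a stated time of 15 min, in the presence of a further agent that is not named here (a lower number here means a stronger inhibitor, a higher number a weaker inhibitor), compound 1 gives 3.4 nM. Compound 2 `CCCC[S+]([O-])c1sc2nc(-c3nccs3)cc(-c3ccc(CO)cc3)c2c1N` has the free hydroxyl there, and in this assay compound 2 gives 2.5 nM. The step between them, a 1.4-fold lower number from compound 1 to compound 2 (0.13 log units; within the scatter), shows that removing the carbamate leaves the number essentially unchanged. Among the numbers so far compound 2 has the lowest value, but its only neighbour, compound 1, stands within the scatter, so no order between the two can be claimed.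

Compound 3 `CCCC[S+]([O-])c1sc2nc(-c3nccs3)cc(-c3ccc(CNS(C)(=O)=O)cc3)c2c1N` is not yet measured. Its difference from compound 2 is methanesulfonamido in place of hydroxy on a saturated chain carbon bound to an aromatic carbon. Within the data shown here, the single step that bears on this position, a 1.4-fold lower number from compound 1 to compound 2 (0.13 log units; within the scatter), is within the scatter, so this end of the molecule has so far tolerated a change of substituent without a shift beyond noise. On that basis no step beyond the scatter is expected here either; the expected step is a 1.4-fold higher number from compound 2 to compound 3 (0.15 log units; within the scatter). Compound 3 is estimated at 3.5 nM in this assay, with a likely range from 1.2 nM to 10 nM.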

Compound 3, half-maximal inhibitory concentration: 4.6 nM
Estimate against measurement, compound 3: 1.3-fold (0.12 log units) below, within the range that was stated.
By their numbers in this assay, from the lowest: compounds 2, 1 and 3 (each within the scatter of the next).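

In this assay the swap of hydroxy for methanesulfonamido, with 5 heavy atoms entering where 1 leaves, gives a 1.8-fold higher number from compound 2 to compound 3 (0.26 log units; within the scatter) and stays within the scatter. Replacing the (ethylcarbamoyl)oxy group with the same methanesulfonamido gives a 1.4-fold higher number from compound 1 to compound 3 (0.13 log units; within the scatter) and also stays within the scatter, so all three pairs at this position now lie within it, and the saturated chain carbon bound to an aromatic carbon has accepted a group attached through nitrogen as well as the two attached through oxygen. No supporting measurement accompanies these numbers to explain this tolerance.

Still open, going by these compounds, is whether an amine, a carboxylic acid or a longer chain ending in hydroxy at this place would also remain within the scatter of these three compounds. The three compounds also share one core, so they leave open whether the same tolerance for hydroxy, (ethylcarbamoyl)oxy and methanesulfonamido would hold with another group in place of the thiazole or the butylsulfinyl chain.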